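Extending the Hydroxycarbamoyl Chain Once More

The source may hold more compounds than are shown below. What is called first, only, known or untested is meant among the compounds shown, and "the series" means these compounds.

Three measured compounds share one core and differ only in the saturated chain on an aromatic nitrogen. They were tested in a functional assay on HCT-116 cells (Homo sapiens) for inhibition, read by MTT assay, with a stated time of 72 h; on this read-out higher numbers stand for weaker inhibition and lower numbers for stronger inhibition. Compound 1 `Nc1nc2cc(-c3nn(CCCC(=O)NO)c4ncnc(N)c34)ccc2o1`, with a 3-(hydroxycarbamoyl)propyl chain, gives 19600 nM. Compound 2 `Nc1nc2cc(-c3nn(CCC(=O)NO)c4ncnc(N)c34)ccc2o1`, with a 2-(hydroxycarbamoyl)ethyl chain, gives > 100000 nM, which is a limit of the assay and not a number. Within the data shown here, compound 3 `Nc1nc2cc(-c3nn(CCCCC(=O)NO)c4ncnc(N)c34)ccc2o1`, with a 4-(hydroxycarbamoyl)butyl chain, gives 34000 nM, which lies within the scatter of the only other true number in the set, that of compound 1.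

Compound 4 `Nc1nc2cc(-c3nn(CCCCCC(=O)NO)c4ncnc(N)c34)ccc2o1` extends the chain again: (hydroxycarbamoyl)methyl in place of hydroxycarbamoyl on a saturated chain carbon, four bonds along the chain from an aromatic nitrogen. In words, (hydroxycarbamoyl)methyl stands in place of hydroxycarbamoyl on a saturated chain carbon, four bonds along the chain from an aromatic nitrogen.

Among the measured compounds shown here, the closest precedent is a 1.7-fold higher number from compound 1 to compound 3 (0.24 log units; within the scatter), the same kind of extension made one position earlier. The steps of an at least 5.1-fold higher number from compound 1 to compound 2 (0.70 log units; beyond the scatter) and an at least 2.9-fold lower number from compound 2 to compound 3 (0.46 log units; beyond the scatter) are beyond the scatter, but both rest on the limit of compound 2, so they give no exact size. No step beyond the scatter is therefore expected in this assay. The expected step is a 1.4-fold lower number from compound 3 to compound 4 (0.13 log units; within the scatter). The estimated value for compound 4 is 25000 nM, with an expected range from 8000 nM to 70000 nM.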

Compound 4, half-maximal inhibitory concentration: 21500 nM
Estimate against measurement, compound 4: 1.2-fold (0.07 log units) above; measured number inside the range.
By their numbers in this assay, from the lowest: compounds 1, 4 and 3 (each within the scatter of the next). At a limit, above all of these: compound 2.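

In this assay, a further extension of the chain cannot be told apart from the two chains before it, with a 1.6-fold lower number from compound 3 to compound 4 (0.20 log units; within the scatter) and a 1.1-fold higher number from compound 1 to compound 4 (0.04 log units; within the scatter). Three chain lengths now sit level, and only the shortest chain stands apart, with an at least 4.6-fold lower number from compound 2 to compound 4 (0.66 log units; beyond the scatter), a step that gives no exact size as it rests on a limit of the assay. The same change in chain length does not count equally at every length on this core: the same change on two cores in this assay, an at least 5.1-fold higher number (0.70 log units; beyond the scatter) from compound 1 to compound 2 and a 1.6-fold higher number (0.20 log units; within the scatter) from compound 4 to compound 3, at least 3.2-fold (0.50 log units) apart, beyond the scatter of two such steps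

As far as these compounds go, a still longer chain could show whether this level continues or finally breaks, and that remains open. From the compounds shown here alone, the role of the hydroxycarbamoyl end also remains open, and a carboxylic acid in its place on the same chains would test it.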